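Chain extension at the triazole: compound 2 toward compound 3

The source may report more compounds than this note shows. Statements on the series, on what has been measured and on what is new or still open speak of the compounds shown alone.

For the measured compounds named here, compound 2 `CCCc1cn(C(c2ccccc2)c2cc3cc(Br)ccc3nc2OC)nn1` gives 0.85% in an ADME assay on HEK293 cells (Homo sapiens) for cytotoxicity, read by sulforhodamine B assay, with a stated time of 48 h, tested at 10 uM (on this read-out lower numbers stand for less inhibition and higher numbers for more inhibition at the one concentration tested (going by the name of the read-out)), the lowest of the two numbers so far; its nearest neighbour is compound 1 `CCCCCCCCc1cn(C(c2ccccc2)c2cc3cc(Br)ccc3nc2OC)nn1`, which in this assay gives 14.6%. Going by the values given here, the one step measured is a number 13.8 percentage points lower from compound 1 to compound 2 (beyond the scatter). Compound 3 `COc1nc2ccc(Br)cc2cc1C(c1ccccc1)n1cc(CCCCCO)nn1` differs from compound 2 by 2-hydroxyethyl in place of hydrogen on a saturated chain carbon, three bonds along the chain from an aromatic carbon. Among the compounds with values here, the only bearing step runs the other way in size, where a longer chain went with a modestly higher number, yet here the entering group carries a hydroxyl, for which no comparison exists. A small rise, at the edge of the scatter, is expected: a number 4.2 percentage points higher from compound 2 to compound 3 (within the scatter). Compound 3 is therefore estimated at 5%, within -4% to 16%.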

Compound 3, a percentage reported as inhibition, at one concentration (the size of the read-out at that concentration, not a potency): 7.96%
The estimate for compound 3 lay 3 percentage points below the measured number; the measured number falls inside the stated range.
By their numbers in this assay, from the lowest: compounds 2, 3 and 1 (each within the scatter of the next, the first and the last beyond it).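

In this assay, compound 3 with its 5-hydroxypentyl chain cannot be separated from either neighbour: a number 7.1 percentage points higher from compound 2 to compound 3 (within the scatter), and a number 6.6 percentage points lower from compound 1 to compound 3 (within the scatter). For the compounds shown here, the hydroxyl is thus the first polar-free reading of a heteroatom at this position, and neither change moves the number beyond the scatter, unlike the step between the two plain chains. No evidence on the cause of these numbers is at hand. Open remain an amine or a carboxylic acid at the chain end, and a longer chain carrying a hydroxyl.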